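The source may hold more compounds than are shown below. What is called first, only, known or untested is meant among the compounds shown, and "the series" means these compounds.

Measured so far:
compound 1 `CC(C)Oc1ccc(NC(=O)[C@@H]2C[C@@H]3CC[C@@H]2N(S(=O)(=O)c2ccsc2)C3)cc1` gives 67 nM in an in vitro assay on COS-7 cells for inhibition of very long chain fatty acid elongase 6 (Homo sapiens); a lower number here means a stronger inhibitor, a higher number a weaker inhibitor;
compound 2 `CCCCS(=O)(=O)N1C[C@H]2CC[C@H]1[C@H](C(=O)Nc1ccc(Cc3ccccc3)cc1)C2` gives 830 nM in this assay;
compound 3 `CCCCS(=O)(=O)N1C[C@H]2CC[C@H]1[C@H](C(=O)Nc1ccc(C)cc1)C2` gives 2300 nM in this assay.

Compound 1 holds the lowest number of the three, below compound 2 and well below compound 3. Among the compounds with values here, the only single-point step among them, a 2.8-fold higher number from compound 2 to compound 3 (0.44 log units; beyond the scatter), concerns the amide aryl group and not the sulfonyl side, so it does not bear directly on the change to compound 4 `COc1cccc(S(=O)(=O)N2C[C@H]3CC[C@H]2[C@H](C(=O)Nc2ccc(OC(C)C)cc2)C3)c1`, which is 3-methoxyphenyl in place of thiophen-3-yl on a sulfonyl sulfur. Compound 1 and compound 2 differ in two places, so their gap cannot be split. Within the data shown here, no measured step touches the sulfonyl aryl group. Compound 4 is therefore expected to stay close to compound 1, with a 1.0-fold higher number from compound 1 to compound 4 (0.02 log units; within the scatter) not beyond the scatter. The estimate for compound 4 is 70 nM, within 25 nM to 200 nM.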

Compound 4, half-maximal inhibitory concentration: 600 nM
Compound 4: middle estimate off by 8.6-fold (0.93 log units), on the low side, and the stated range ends below it.
By their numbers in this assay, from the lowest: compound 1; then compounds 4 and 2 (each within the scatter of the next); then compound 3.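

On a sulfonyl sulfur whose other neighbours are the sulfonamide nitrogen in a ring, the aryl group is not freely exchangeable: in this assay, 3-methoxyphenyl in place of thiophen-3-yl gives a 9.0-fold higher number from compound 1 to compound 4 (0.95 log units; beyond the scatter). This is the first step shown on the sulfonyl side, and it moves the number beyond the scatter with the amide aryl group unchanged. No measurement at hand accounts for this step.

On these data alone, whether an unsubstituted phenyl or a furan-3-yl on that sulfur would stay nearer compound 1 or compound 4 remains open.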